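Replacing 2-chloro-4-nitrophenyl on an amine nitrogen

This account rests on a few compounds, and the source may have more. Where it says the series, first, only, none or still open, it means among the compounds named here.

Measured in a functional assay on A-431 cells (Homo sapiens) for inhibition, read by sulforhodamine B assay, with a stated time of 2 days; a lower number here means a stronger inhibitor of growth, a higher number a weaker inhibitor of growth:
compound 1 `CC1=C(C(=O)Nc2ccc(C)cc2)C(c2ccc(O)cc2O)NC(Nc2ccc([N+](=O)[O-])cc2Cl)=N1` gives 31900 nM
compound 2 `CC1=C(C(=O)Nc2cccc([N+](=O)[O-])c2)C(c2ccc(O)cc2O)NC(Nc2ccc([N+](=O)[O-])cc2Cl)=N1` gives 3940 nM
compound 3 `Cc1ccc(NC(=O)c2c(C)nc(S(=O)(=O)Cc3ccccc3)nc2-c2ccc(O)cc2O)cc1` gives 32000 nM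

Compound 2 has the lowest number of the three, and compound 1 and compound 3 both stand well above it. The next analogue is compound 4 `CC1=C(C(=O)Nc2cccc([N+](=O)[O-])c2)C(c2ccc(O)cc2O)NC(N/N=C/c2ccco2)=N1` and the change is a group of 7 heavy atoms (5 carbon, 1 nitrogen, 1 oxygen; one five-membered aromatic ring with 1 hetero atom) in place of a group of 10 heavy atoms (6 carbon, 1 nitrogen, 2 oxygen, 1 chlorine; one six-membered aromatic ring of carbon only), on an amine nitrogen with 2-chloro-4-nitrophenyl as the group that leaves. Among the measured compounds shown here, only one measured step is available, an 8.1-fold lower number from compound 1 to compound 2 (0.91 log units; beyond the scatter) but it lies at another place, on an amide-type nitrogen. For the measured compounds named here, it shows how far one exchange has moved the numbers in this small set, yet no measured step touches the amine nitrogen. With compound 2 at 3940 nM holding the lowest number, a rise is more likely than a further fall. A modest weakening, a 2.0-fold higher number from compound 2 to compound 4 (0.31 log units; beyond the scatter) is expected, an estimate no larger than the amide step. Compound 4 is expected near 8000 nM with an estimated range from 2000 nM to 32000 nM in this assay when it is tested.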

Compound 4, concentration for 50% growth inhibition: 2910 nM
Beside the measured number, compound 4's estimate is 2.7-fold (0.44 log units) above it; the range from low to high includes it.
By their numbers in this assay, from the lowest: compounds 4 and 2 (each within the scatter of the next); then compounds 1 and 3 (each within the scatter of the next).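

In this assay, among the compounds shown here, the first measured step at the amine nitrogen, a 1.4-fold lower number from compound 2 to compound 4 (0.13 log units; within the scatter), shows that the two compounds cannot be told apart in this pair. With the 3-nitrophenyl amide held constant, the group with a five-membered aromatic ring can stand in place of 2-chloro-4-nitrophenyl without a change beyond the scatter, whereas the earlier exchange at the amide-type nitrogen gave an 8.1-fold lower number from compound 1 to compound 2 (0.91 log units; beyond the scatter). Nothing available bears on why this position and that one differ in this way.

As far as these compounds go, whether the same exchange would read alike with 4-methylphenyl on the amide-type nitrogen remains open. From the compounds shown here alone, it is also open how a longer alkyl chain or a carboxylic acid on the amine nitrogen would read in this assay.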